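The source may hold more compounds than are shown below. What is called first, only, known or untested is meant among the compounds shown, and "the series" means these compounds.

Compound 1 `Cc1cc(/C=C2\S/C(=N\c3ccccc3)N(C)C2=O)c(C)n1-c1ccccc1`: > 230000 nM, a limit of the assay
Compound 2 `Cc1cc(/C=C2\SC(=O)NC2=O)c(C)n1-c1ccccc1C(F)(F)F`: 64000 nM

Within the data shown here, in an ADME assay on L6 cells (Rattus norvegicus) for cytotoxicity, read by microscopy and resazurin assay, with a stated time of 72 h (a higher number here means that more compound is needed for the effect, a lower number that less compound is needed), compound 2 gives 64000 nM, the only actual number so far. Compound 1 reports only a limit, > 230000 nM.

Compound 3 `Cc1cc(/C=C2/SC(=N)NC2=O)c(C)n1-c1ccccc1C(F)(F)F` differs from compound 2 in one place, on an aromatic carbon: a group of 8 heavy atoms (4 carbon, 2 nitrogen, 1 oxygen, 1 sulfur; one five-membered non-aromatic ring with 2 hetero atoms) in place of a group of 8 heavy atoms (4 carbon, 1 nitrogen, 2 oxygen, 1 sulfur; one five-membered non-aromatic ring with 2 hetero atoms), on an aromatic carbon. Among the measured compounds shown here, no measured step shows what such a swap does, so the expectation starts from compound 2 at 64000 nM. A small move towards lower numbers is expected, a 1.4-fold lower number from compound 2 to compound 3 (0.15 log units; within the scatter), possibly no larger than the usual scatter. Compound 3 is estimated at 45000 nM, with an expected range of 14000 nM to 140000 nM.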

Compound 3, half-maximal effective concentration: 56000 nM
Compound 3: middle estimate off by 1.2-fold (0.09 log units), on the low side, and the stated range covers the measured number.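

Among these compounds, this is the first measured step at this aromatic carbon of the five-membered aromatic ring. In this assay, replacing the group with 1 hydrogen-bond donor by the group with 2 gives a 1.1-fold lower number from compound 2 to compound 3 (0.06 log units; within the scatter), so this swap leaves the reading practically unchanged. Nothing measured here bears on the cause of this result.

Still open, going by these compounds, is what a group of a different kind at this place would do, such as an amine or a carboxylic acid in place of the five-membered non-aromatic ring.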